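Swapping the aryl on the hydrazone carbon: cytotoxicity expectation

The source may report more compounds than this note shows. Statements on the series, on what has been measured and on what is new or still open speak of the compounds shown alone.

Compound 1 `COc1ccccc1-c1nnc(-c2ccc(C(=O)N/N=C/c3cc(O)ccc3O)cc2)o1`: 100000 nM
Compound 2 `COc1ccccc1-c1nnc(-c2ccc(C(=O)N/N=C/c3ccncc3)cc2)o1`: 173000 nM

In an ADME assay on THP-1 cells (Homo sapiens) for cytotoxicity (a lower number here means a stronger inhibitor, a higher number a weaker inhibitor), compound 2 gives the highest of the two numbers; its nearest neighbour is compound 1, and the two sit within the scatter of each other. Compound 3 `COc1ccc(/C=N/NC(=O)c2ccc(-c3nnc(-c4ccccc4OC)o3)cc2)c(O)c1` differs from compound 2 by 2-hydroxy-4-methoxyphenyl in place of pyridin-4-yl on a carbon with a double bond to nitrogen. Among the compounds with values here, the only step that bears on this is a 1.7-fold higher number from compound 1 to compound 2 (0.24 log units; within the scatter), which runs the other way round the same carbon. A step of similar smallness is therefore expected, here a 1.6-fold lower number from compound 2 to compound 3 (0.20 log units; within the scatter), giving compound 3 an estimated 110000 nM with a range from 50000 nM to 250000 nM.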

Compound 3, half-maximal inhibitory concentration: 308000 nM
Compound 3: the middle estimate sits 2.8-fold (0.45 log units) below what was measured; measured number above the stated range.
By their numbers in this assay, from the lowest: compounds 1, 2 and 3 (each within the scatter of the next, the first and the last beyond it).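

In this assay, this position on the carbon with a double bond to nitrogen now gives a step beyond the scatter: a 3.1-fold higher number from compound 1 to compound 3 (0.49 log units; beyond the scatter) when 2-hydroxy-4-methoxyphenyl replaces 2,5-dihydroxyphenyl. Against pyridin-4-yl, the same group gives a 1.8-fold higher number from compound 2 to compound 3 (0.25 log units; within the scatter), so pyridin-4-yl cannot be told apart from either substituted phenyl group. Nothing measured here explains the gap between those two groups. Still open, from the compounds shown here alone, is how a phenyl ring carrying an amine or a carboxylic acid would read here. Also open, going by these compounds, is whether the methoxy group alone matters in compound 3.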